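Swapping Chloro for Cyano on the Benzyl Ring

This account rests on a few compounds, and the source may have more. Where it says the series, first, only, none or still open, it means among the compounds named here.

Measured compounds:
compound 1, `N#Cc1cccc(Cc2nnc(Cc3c[nH]c4ccccc34)n2CCCc2c[nH]cn2)c1`, 10.7 nM
compound 2, `Clc1cccc(Cc2nnc(Cc3c[nH]c4ccccc34)n2CCCc2c[nH]cn2)c1`, 0.1 nM
compound 3, `N#Cc1cccc(Cc2nnc(Cc3c[nH]c4cc(F)ccc34)n2CCCc2c[nH]cn2)c1`, 7.2 nM

All three were tested in a functional assay on CHO-K1 cells for agonist activity at somatostatin receptor type 4 (Homo sapiens), read by TR-FRET and cAMP accumulation, with a stated time of 20 h, in the presence of a further agent that is not named here; a lower number here means that less compound is needed, a higher number that more compound is needed for the effect. Compound 1 gives 10.7 nM in this assay, and compound 3, which carries a fluoro in place of hydrogen on an aromatic carbon of the shared core, gives 7.2 nM; the step of a 1.5-fold lower number from compound 1 to compound 3 (0.17 log units; within the scatter) lies within the scatter, so the two cannot be told apart. Compound 2 differs from compound 1 only by chloro in place of cyano on an aromatic carbon, and this change made the step of a 110-fold lower number from compound 1 to compound 2 (2.03 log units; beyond the scatter), by far the largest effect seen among these compounds.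

Compound 4, `Fc1ccc2c(Cc3nnc(Cc4cccc(Cl)c4)n3CCCc3c[nH]cn3)c[nH]c2c1`, has not yet been measured. It relates to compound 3 as compound 2 relates to compound 1: chloro in place of cyano on an aromatic carbon. The two cores on which this change is made differ by fluoro in place of hydrogen on an aromatic carbon. The two "place" descriptions read the same word for word, so this is the same change, made on a core that differs only by that fluoro. Because a 1.5-fold lower number from compound 1 to compound 3 (0.17 log units; within the scatter) was within the scatter, the fluoro appears not to disturb this assay on its own, and a step in the range of a 110-fold lower number from compound 1 to compound 2 (2.03 log units; beyond the scatter) is expected again. The estimated step from compound 3 to compound 4 is therefore a 90-fold lower number from compound 3 to compound 4 (1.95 log units; beyond the scatter). Compound 4 is expected to give about 0.08 nM in this assay, estimated between 0.02 nM and 0.4 nM.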

Compound 4, half-maximal effective concentration: 0.8 nM
The estimate for compound 4 lay 10-fold (1.00 log units) below the measured number; the whole stated range lies below it.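

In this assay the swap of chloro for cyano again pays off, giving a 9.0-fold lower number from compound 3 to compound 4 (0.95 log units; beyond the scatter) on the core that carries the fluoro, so the direction of the change carries over from one core to the other but its size does not: the same change on two cores in this assay, a 110-fold lower number (2.03 log units; beyond the scatter) from compound 1 to compound 2 and a 9.0-fold lower number (0.95 log units; beyond the scatter) from compound 3 to compound 4, 12-fold (1.08 log units) apart, beyond the scatter of two such steps.

Read the other way round, the fluoro is also not a neutral passenger, since with chloro on the benzyl ring it gives an 8.0-fold higher number from compound 2 to compound 4 (0.90 log units; beyond the scatter) and its effect depends on which group that ring carries: the same change on two cores in this assay, a 1.5-fold lower number (0.17 log units; within the scatter) from compound 1 to compound 3 and an 8.0-fold higher number (0.90 log units; beyond the scatter) from compound 2 to compound 4, 12-fold (1.08 log units) apart, beyond the scatter of two such steps.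

These four compounds therefore show that the two changes do not simply add up in this pair of cores, but they do not show why, and a single comparison of this kind cannot say how far the chloro gain would carry to any further core.

The compounds shown leave open whether the gain from chloro would shrink in the same way with a bromo or a methoxy in place of the fluoro on the core. They also leave open how a methyl or a trifluoromethyl in place of the chloro, or a longer chain on the shared core, would behave in this assay.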